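Chlorophenyl isomers and solubility across two related cores

The source may hold more compounds than are shown below. What is called first, only, known or untested is meant among the compounds shown, and "the series" means these compounds.

Three analogues have been measured in a physicochemical assay for solubility, in phosphate buffer, at pH 7.4; on this read-out lower numbers stand for lower solubility and higher numbers for higher solubility. Compound 1 `CCOC(=O)c1c(-c2ccc(Cl)cc2)[nH]c2cccc(OC)c2c1=O` reports a limit of the assay, > 100000 nM, and not a number. Compound 2 `CCOC(=O)c1c(-c2cccc(Cl)c2)[nH]c2cccc(OC)c2c1=O` likewise sits at a limit, > 100000 nM. Among the compounds with values here, compound 3 `CCOC(=O)c1c(-c2cccc(Cl)c2)[nH]c2cc(OC)ccc2c1=O` is the only compound with a number, giving 58000 nM in this assay. The change 4-chlorophenyl in place of 3-chlorophenyl on an aromatic carbon makes the step that the two limits leave unreadable from compound 2 to compound 1, which the two limits leave unreadable; the evidence here is the limit of > 100000 nM in this assay, at which 2 of the 3 values shown sit. The difference between the core of compound 2 and the core of compound 3 is not broken down here.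

Compound 4 `CCOC(=O)c1c(-c2ccc(Cl)cc2)[nH]c2cc(OC)ccc2c1=O` is not yet measured. It differs from compound 3 by 4-chlorophenyl in place of 3-chlorophenyl on an aromatic carbon, the same change as from compound 2 to compound 1, at a place described in identical words.

Compound 4 is expected to give about 60000 nM in this assay, within 25000 nM to 140000 nM. The expected step is a 1.0-fold higher number from compound 3 to compound 4 (0.01 log units; within the scatter). This expectation rests on compound 3 at 58000 nM and on the step that the two limits leave unreadable from compound 2 to compound 1 offering no readable size, so no direction is assumed.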

Compound 4, solubility: 3000 nM
Estimate against measurement, compound 4: 20-fold (1.30 log units) above; measured number below the stated range.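

In this assay, 4-chlorophenyl in place of 3-chlorophenyl on the core of compound 3 gives a 19-fold lower number from compound 3 to compound 4 (1.29 log units; beyond the scatter), so on this core the change is not neutral. The same change on the other core, from compound 2 to compound 1, cannot be read, since both compounds sit at a limit and not at a number: the limit of > 100000 nM in this assay, at which 2 of the 4 values shown sit. The series therefore holds one readable pair, which shows what the change does on the core of compound 3 but neither shows nor rules out that the step carries over to the core of compound 2, and it gives no cause for the step.

The compounds shown leave open whether the drop seen at compound 4 depends on the core or would appear on both cores if the values on the core of compound 2 could be read. Also open, on these data alone, is how either core would respond to an amine or a carboxylic acid in place of the ethoxycarbonyl group.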